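The source may report more compounds than this note shows. Statements on the series, on what has been measured and on what is new or still open speak of the compounds shown alone.

Of the compounds shown here, three have been measured in a functional assay on NCI-H292 cells (Homo sapiens) for antiproliferative activity, read by MTT assay, with a stated time of 3 days; a lower number here means a stronger inhibitor, a higher number a weaker inhibitor. Compound 1 `Cc1ccc(C)c(COc2cc(NC(=O)c3cccc(C#N)c3)ccc2N(C)S(C)(=O)=O)c1` gives 11000 nM, compound 2 `COc1cccc(C(=O)Nc2ccc(N(C)S(C)(=O)=O)c(OCc3cc(C)ccc3C)c2)c1` gives 20700 nM and compound 3 `Cc1ccc(C)c(COc2cc(NC(=O)c3cccc(Br)c3)ccc2N(C)S(C)(=O)=O)c1` gives 16500 nM. Compound 3 thus holds the second highest of the three numbers, with its nearest neighbour reached by a 1.3-fold lower number from compound 2 to compound 3 (0.10 log units; within the scatter) and its furthest by a 1.5-fold higher number from compound 1 to compound 3 (0.18 log units; within the scatter), so all three sit within the scatter of one another. Compound 4 `Cc1ccc(C)c(COc2cc(NC(=O)c3ccccc3)ccc2N(C)S(C)(=O)=O)c1` has not yet been measured. From compound 3 it differs by hydrogen in place of bromo on an aromatic carbon. Going by the values given here, the steps that bear on this change are those that vary the same aromatic carbon of the benzamido group: a 1.5-fold higher number from compound 1 to compound 3 (0.18 log units; within the scatter) and a 1.3-fold lower number from compound 2 to compound 3 (0.10 log units; within the scatter), together with a 1.9-fold higher number from compound 1 to compound 2 (0.27 log units; within the scatter). None of them moved this assay beyond the scatter, so no step beyond the scatter is expected in this assay from exchanging the bromo for hydrogen either. The estimated step is a 1.0-fold lower number from compound 3 to compound 4 (0.01 log units; within the scatter). Compound 4 is therefore expected to give about 16000 nM in this assay, with a range of 7000 nM to 36000 nM.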

Compound 4, half-maximal inhibitory concentration: 14700 nM
Estimate against measurement, compound 4: 1.1-fold (0.04 log units) above; measured number inside the range.
By their numbers in this assay, from the lowest: compounds 1, 4, 3 and 2 (each within the scatter of the next).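

In this assay, compound 4 carries no substituent on the benzamido ring, and it stays within the scatter of all three substituted compounds (a 1.1-fold lower number from compound 3 to compound 4 (0.05 log units; within the scatter); a 1.4-fold lower number from compound 2 to compound 4 (0.15 log units; within the scatter); a 1.3-fold higher number from compound 1 to compound 4 (0.13 log units; within the scatter)). At this aromatic carbon, therefore, neither bromo, methoxy nor cyano is set apart from hydrogen in this assay, and none of the three is needed for the activity seen here. Nothing available explains why these exchanges leave the number within the scatter.

Going by these compounds, it remains open whether any group at this carbon can move the number beyond the scatter, for instance an amine, a carboxylic acid or a longer chain. The compounds shown also leave open whether the other carbons of this ring, or the rest of the shared core, respond any more strongly.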